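Amide substituent step on the shared core, compound 2 to compound 3

A few compounds are considered here, and "the series" means these few. Any claim that something is new, unique, unknown or untested is made for them only; others in the source may bear on it.

Measured so far:
compound 1 `O=C(/C=C/c1ccccc1)Nc1cc(Sc2ncn[nH]2)c(O)c2ccccc12` — 26.2%
compound 2 `COc1cccc(C(=O)Nc2cc(Sc3ncn[nH]3)c(O)c3ccccc23)c1` — 19.4%

In an assay on isolated protein for inhibition of RAC-alpha serine/threonine-protein kinase (Homo sapiens), read by fluorescence, with a stated time of 30 min, tested at 10 uM (on this read-out higher numbers stand for more inhibition at the one concentration tested (going by the name of the read-out) and lower numbers for less inhibition), compound 1 gives 26.2% and compound 2 gives 19.4%. Compound 2 has the lowest of the two numbers; its nearest neighbour is compound 1, the step being a number 6.8 percentage points lower from compound 1 to compound 2 (within the scatter). Compound 3 `O=C(/C=C/c1ccc(Cl)cc1)Nc1cc(Sc2ncn[nH]2)c(O)c2ccccc12` is to be measured; it differs from compound 2 by 2-(4-chlorophenyl)ethenyl in place of 3-methoxyphenyl on a carbonyl carbon. For the measured compounds named here, the only measured step that bears on this, a number 6.8 percentage points lower from compound 1 to compound 2 (within the scatter), swapped a 2-phenylethenyl for a 3-methoxyphenyl and stayed within the scatter, so returning to an ethenyl-linked phenyl with chlorine added gives no basis for a step beyond the scatter. The expected step from compound 2 to compound 3 is therefore a number 5.6 percentage points higher from compound 2 to compound 3 (within the scatter), upward but small. For compound 3 the estimate in this assay is 25%, ranging from 10% to 42%.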

Compound 3, a percentage reported as inhibition, at one concentration (the size of the read-out at that concentration, not a potency): 31.8%
Compound 3: middle estimate off by 6.8 percentage points, on the low side; measured number inside the range.
By their numbers in this assay, from the lowest: compounds 2, 1 and 3 (each within the scatter of the next, the first and the last beyond it).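

In this assay, a change on the carbonyl carbon now moves the number beyond the scatter: 2-(4-chlorophenyl)ethenyl in place of 3-methoxyphenyl gives a number 12.4 percentage points higher from compound 2 to compound 3 (beyond the scatter) on the shared core. Chloro in place of hydrogen on an aromatic carbon gives only a number 5.6 percentage points higher from compound 1 to compound 3 (within the scatter) and stays within the scatter, so the chlorine alone does not separate compound 3 from compound 1. No evidence at hand bears on the reason for either step.

Still open, going by these compounds, is how an amine, a carboxylic acid or a longer chain on the carbonyl carbon would read in this assay. Fluoro or methoxy in place of chloro on the 2-phenylethenyl is equally open.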